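A few compounds are considered here, and "the series" means these few. Any claim that something is new, unique, unknown or untested is made for them only; others in the source may bear on it.

In a functional assay on MCF7 cells (Homo sapiens) for inhibition, read by MTT assay, with a stated time of 72 h (on this read-out lower numbers stand for stronger inhibition and higher numbers for weaker inhibition), compound 1 (`COc1cc2c(Oc3ccc(NC(=O)c4nn(-c5ccccc5C)cc(C)c4=O)cc3F)ccnc2cc1OCCCC(=O)NO`) gives 2600 nM and compound 2 (`COc1cc2c(Oc3ccc(NC(=O)c4nn(-c5ccccc5F)cc(C)c4=O)cc3)ccnc2cc1OCCCC(=O)NO`) gives 2650 nM and these two values lie within the scatter of each other, which places compound 2 level with compound 1. Compound 3 (`COc1cc2c(Oc3ccc(NC(=O)c4nn(-c5ccccc5C)cc(C)c4=O)cc3)ccnc2cc1OCCCC(=O)NO`) differs from compound 2 in one place (methyl in place of fluoro on an aromatic carbon) with methyl in place of fluoro on an aromatic carbon, so that 2-fluorophenyl becomes 2-methylphenyl. Within the data shown here, no step between measured compounds shows what this change does, so the expectation rests on compound 2 at 2650 nM as the nearest measured reference. In this assay no step beyond the scatter is expected, in either direction. The estimated 1.1-fold lower number from compound 2 to compound 3 (0.03 log units; within the scatter) is small and stays within the scatter. For compound 3 the expected value is 2500 nM with an estimated range from 1100 nM to 5500 nM as a working figure.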

Compound 3, half-maximal inhibitory concentration: 1600 nM
For compound 3 the middle estimate is 1.6-fold (0.19 log units) above the measured one; measured number inside the range.
By their numbers in this assay, from the lowest: compounds 3, 1 and 2 (each within the scatter of the next).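

Going from 2-fluorophenyl to 2-methylphenyl, at the place ortho to a large group, gives in this assay a 1.7-fold lower number from compound 2 to compound 3 (0.22 log units; within the scatter), so this swap of one heavy atom for another does not separate the two compounds at this position. The second change, the loss of a single fluoro, gives a 1.6-fold lower number from compound 1 to compound 3 (0.21 log units; within the scatter), so that fluoro can also be absent without a step beyond the scatter. Nothing available explains either step.

The compounds shown carry only fluoro and methyl at the place ortho to a large group, so it remains open whether a larger or differently built group, such as trifluoromethyl, methoxy or an amine, would give a step beyond the scatter. From the compounds shown here alone, it is equally open whether chloro at the other fluoro-bearing carbon would behave as hydrogen and fluoro do.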